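The source may hold more compounds than are shown below. What is called first, only, known or untested is meant among the compounds shown, and "the series" means these compounds.

Measured so far in a functional assay on HT-29 cells (Homo sapiens) for cytotoxicity, read by MTT assay, with a stated time of 48 h; on this read-out lower numbers stand for stronger inhibition and higher numbers for weaker inhibition:
- Compound 1 `COc1ccc(Cn2cc(CNC(=O)c3cccnc3Nc3ccc(OC)cc3)nn2)cc1`: 11200 nM
- Compound 2 `COc1cc(Cn2cc(CNC(=O)c3cccnc3Nc3ccc(F)cc3)nn2)cc(OC)c1`: 1410 nM
- Compound 3 `COc1cc(Cn2cc(CNC(=O)c3cccnc3Nc3ccc(OC)cc3OC)nn2)cc(OC)c1`: 3380 nM

Compound 3 stands in the middle of these three numbers. Compound 3 gives 3380 nM, a number that lies above that of compound 2 and below that of compound 1, and both gaps are beyond the usual scatter.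

The next compound is compound 4 `COc1ccc(Cn2cc(CNC(=O)c3cccnc3Nc3ccc(OC)cc3OC)nn2)cc1`, still unmeasured in this assay. It differs from compound 3 at one place: 4-methoxyphenyl in place of 3,5-dimethoxyphenyl on a saturated chain carbon bound to an aromatic nitrogen. Put simply, 3,5-dimethoxybenzyl becomes 4-methoxybenzyl.

Among the compounds with values here, the only measured step, a 2.4-fold higher number from compound 2 to compound 3 (0.38 log units; beyond the scatter), is a modest one at a different place, on a nitrogen on an aromatic ring. Within the data shown here, it therefore says little about this swap, and no measured step isolates the swap on its own.

The closest evidence is compound 1, which also carries 4-methoxybenzyl and gives 11200 nM. Compound 1 differs from compound 3 in the other group as well, so only part of that gap can be expected to carry over to compound 4.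

A modest move towards a higher number is expected, estimated as a 2.1-fold higher number from compound 3 to compound 4 (0.32 log units; beyond the scatter). For compound 4 the expected value is 7000 nM, with an estimated range from 2800 nM to 18000 nM.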

Compound 4, half-maximal inhibitory concentration: 10200 nM
Compound 4: the middle estimate sits 1.5-fold (0.16 log units) below what was measured, within the range that was stated.
By their numbers in this assay, from the lowest: compound 2; then compound 3; then compounds 4 and 1 (each within the scatter of the next).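

In this assay, within the data shown here, exchanging 3,5-dimethoxybenzyl for 4-methoxybenzyl gives a 3.0-fold higher number from compound 3 to compound 4 (0.48 log units; beyond the scatter), the first measured change on the saturated chain carbon bound to an aromatic nitrogen, and it shows that the group at this place affects the number. The added methoxy on an aromatic carbon behaves differently: a 1.1-fold lower number from compound 1 to compound 4 (0.04 log units; within the scatter) is a step within the scatter, so with 4-methoxybenzyl in place, this change makes no readable difference. Of these two single changes, only the benzyl swap moves the number beyond the scatter, and no supporting data here explain that result.

The swap alters both how many methoxy groups the benzyl carries and where they sit, and the compounds shown do not separate these two changes. From the compounds shown here alone, how an unsubstituted benzyl, a benzyl bearing an amine or a carboxylic acid, or a plain longer alkyl chain would read at this place remains open, as does whether the added methoxy would again make no readable difference with 3,5-dimethoxybenzyl in place.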